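A few compounds are considered here, and "the series" means these few. Any claim that something is new, unique, unknown or untested is made for them only; others in the source may bear on it.

Measured compounds in a functional assay on A549 cells (Homo sapiens) for inhibition, read by MTT assay, with a stated time of 48 h; a higher number here means a weaker inhibitor, a lower number a stronger inhibitor:
compound 1 `COc1cc(-c2nc3cc(/C=C4\SC(=O)NC4=O)ccc3[nH]2)cc(OC)c1OC`, 3570 nM
compound 2 `COc1cc(-c2nc3cc(/C=C4\SC(=O)N(CC(=O)N5CCCC5)C4=O)ccc3[nH]2)cc(OC)c1OC`, 910 nM

Of these two numbers, compound 2 stands lowest, which means it is the stronger inhibitor of the pair. Compound 3 `COc1cc(-c2nc3cc(/C=C4\SC(=O)N(Cc5ccccc5)C4=O)ccc3[nH]2)cc(OC)c1OC` differs from compound 2 by phenyl in place of (pyrrolidin-1-yl)carbonyl on a saturated chain carbon bound to an amide-type nitrogen in a ring. Within the data shown here, the only measured step, a 3.9-fold lower number from compound 1 to compound 2 (0.59 log units; beyond the scatter), concerns putting a group onto that ring nitrogen where before there was hydrogen, not swapping one group for another, so it bears only loosely here. Since compound 3 still carries a substituent on that nitrogen, compound 3 is expected to give 1100 nM in this assay, in a range from 400 nM to 3200 nM. This expected step, a 1.2-fold higher number from compound 2 to compound 3 (0.08 log units; within the scatter), is not beyond the scatter.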

Compound 3, half-maximal inhibitory concentration: 670 nM
The estimate for compound 3 lay 1.6-fold (0.22 log units) above the measured number; the measured number falls inside the stated range.
By their numbers in this assay, from the lowest: compounds 3 and 2 (each within the scatter of the next); then compound 1.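

In this assay, swapping ((pyrrolidin-1-yl)carbonyl)methyl for benzyl on the amide-type nitrogen in a ring changes little (a 1.4-fold lower number from compound 2 to compound 3 (0.13 log units; within the scatter)), so the carbonyl and the pyrrolidine ring are not needed to keep this level of inhibition. Benzyl in place of hydrogen on that nitrogen also gives a lower number (a 5.3-fold lower number from compound 1 to compound 3 (0.73 log units; beyond the scatter)), so both substituents shown improve on the hydrogen. Nothing available explains why these two groups give such similar values. As far as these compounds go, it remains open whether a longer chain between the nitrogen and the phenyl, or a chain ending in an amine or a carboxylic acid, would keep this inhibition. Fluorine or methoxy on the phenyl ring is equally untested among these compounds.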